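The source may report more compounds than this note shows. Statements on the series, on what has been measured and on what is new or still open speak of the compounds shown alone.

Values in a functional assay on DU-145 cells (Homo sapiens) for cytotoxicity, read by MTT assay, with a stated time of 48 h; a higher number here means a weaker inhibitor, a lower number a stronger inhibitor:
compound 1 `COc1ccc(/C=C/c2cc(OC)c(OC)c(OC)c2-c2ccc(F)c(F)c2)cc1`: 7500 nM
compound 2 `COc1cc(/C=C/c2ccccc2)c(-c2ccccc2)c(OC)c1OC`: 82000 nM
compound 3 `C=C(c1ccc(OC)cc1)c1cc(OC)c(OC)c(OC)c1-c1ccc(OC)cc1`: 37000 nM

Compound 2 has the highest number of the three, with compound 3 the nearest to it and compound 1 the furthest. Compound 4 `C=C(c1ccccc1)c1cc(OC)c(OC)c(OC)c1-c1ccccc1` has the same atoms as compound 2, joined differently: 1-phenylethenyl in place of 2-phenylethenyl on an aromatic carbon. The new group stands ortho to a phenyl group. Within the data shown here, no measured pair isolates this change. Among the measured compounds shown here, the only guide is compound 3 at 37000 nM, which carries a substituted form of 1-phenylethenyl but also differs from compound 4 elsewhere. A moderate step to a lower number is expected, and the estimated step is a 2.3-fold lower number from compound 2 to compound 4 (0.37 log units; beyond the scatter). For compound 4 the estimated value is 35000 nM, with an expected range of 12000 nM to 100000 nM.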

Compound 4, half-maximal inhibitory concentration: 36000 nM
The estimate for compound 4 lay 1.0-fold (0.01 log units) below the measured number; low and high end bracket the measured number.
By their numbers in this assay, from the lowest: compound 1; then compounds 4 and 3 (each within the scatter of the next); then compound 2.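

In this assay, 1-phenylethenyl in place of 2-phenylethenyl, on the aromatic carbon ortho to a phenyl group, gives a 2.3-fold lower number from compound 2 to compound 4 (0.36 log units; beyond the scatter). Among these compounds, this is the first reading of this change alone: the atoms stay the same, and only the attachment of the phenylethenyl group differs, so the attachment by itself moves the number modestly. No measurement here accounts for the step.

From the compounds shown here alone, whether the step carries over to compounds with substituted aromatic rings stays open. So does the effect of an amine or a carboxylic acid on the 1-phenylethenyl group.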